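The source may report more compounds than this note shows. Statements on the series, on what has been measured and on what is new or still open speak of the compounds shown alone.

Measured compounds:
- compound 1, `CC(CO)(CCC[S+]([O-])CCCC(C)(CO)c1ccccc1)c1ccccc1`: in a functional assay on cells (Hepatocyte, Rattus norvegicus, strain Sprague-Dawley) for inhibition (a higher number here means a weaker inhibitor, a lower number a stronger inhibitor), compound 1 is reported as "not active" (no number reported), with no number given.
- compound 2, `CC(CCCCSCCCCC(C)(C(=O)O)c1ccccc1)(C(=O)O)c1ccccc1`: in this assay compound 2 gives 26000 nM.
- compound 3, `CC(C)(CO)CCCCC(O)CCCCC(C)(C)CO`: in this assay compound 3 gives 6400 nM.

Compound 3 thus holds the lowest of the two numbers reported; the gap to compound 2 lies beyond the usual scatter. Compound 1 contributes no number and cannot be ranked.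

Compound 4, `CC(=O)C(CCCCC(C)(C)CO)CCCCC(C)(C)CO`, differs from compound 3 in one place: acetyl in place of hydroxy on a saturated chain carbon bound to two saturated chain carbons. Among the measured compounds shown here, no step of this kind exists among the measured compounds, so there is no precedent for its size. A small step is expected, more likely toward a higher number in this assay than a lower one, but possibly none beyond the scatter. For compound 4 the expected step is a 1.3-fold higher number from compound 3 to compound 4 (0.10 log units; within the scatter), giving an estimate of 8000 nM with a range of 2500 nM to 25000 nM.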

Compound 4, half-maximal inhibitory concentration: 46000 nM
For compound 4 the middle estimate is 5.8-fold (0.76 log units) below the measured one, outside the stated range (above it).
By their numbers in this assay, from the lowest: compound 3; then compounds 2 and 4 (each within the scatter of the next).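

In this assay, replacing hydroxy with acetyl on a saturated chain carbon bound to two saturated chain carbons gives a 7.2-fold higher number from compound 3 to compound 4 (0.86 log units; beyond the scatter), so this position is sensitive to the change. The earlier compounds shown here offered no step at this position. Nothing available explains the size or direction of this step.

Still open, from the compounds shown here alone, is whether an amine or a methoxy group on this carbon would stay close to compound 3. This single step also cannot separate the loss of hydroxy from the arrival of acetyl.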